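This account rests on a few compounds, and the source may have more. Where it says the series, first, only, none or still open, it means among the compounds named here.

Compound 1 `Cc1ccc(CN2CCN(c3cccc4[nH]c(-c5ccc(C(C)(C)C)cc5)nc34)CC2)o1`: 705 nM
Compound 2 `Cc1nc(CN2CCN(c3cccc4[nH]c(-c5ccc(C(C)(C)C)cc5)nc34)CC2)c[nH]1`: 7.5 nM
Compound 3 `Cc1nc(CN2CCN(c3cccc4[nH]c(-c5ccc(C(C)(C)C)cc5)nc34)CC2)c(C)s1`: 21 nM

Three compounds sharing one core and differing only in the aromatic ring on the saturated chain carbon bound to an amine nitrogen in a ring have been tested in an assay on isolated protein for displacement of a labelled ligand from Gonadotropin-releasing hormone receptor (Homo sapiens); on this read-out higher numbers stand for weaker inhibition and lower numbers for stronger inhibition. Compound 1 stands highest of the three; its nearest neighbour is compound 3, with a 34-fold lower number from compound 1 to compound 3 (1.53 log units; beyond the scatter), and the furthest is compound 2, with a 94-fold lower number from compound 1 to compound 2 (1.97 log units; beyond the scatter). Between the two azoles the gap is smaller, a 2.8-fold higher number from compound 2 to compound 3 (0.45 log units; beyond the scatter).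

Compound 4 `CCCn1c(CC)nc(C)c1CN1CCN(c2cccc3[nH]c(-c4ccc(C(C)(C)C)cc4)nc23)CC1` has not yet been measured in this assay. Its difference from compound 1 is 2-ethyl-4-methyl-1-propyl-1H-imidazol-5-yl in place of 5-methylfuran-2-yl on a saturated chain carbon bound to an amine nitrogen in a ring.

Both measured steps that exchange the 5-methylfuran-2-yl for a five-membered ring with two hetero atoms were large and in the same direction, so a step of that kind is expected here too. Compound 4 carries the imidazole, as compound 2 does, but with the additional alkyl groups and the ring nitrogen substituted, and the data give no direct guide to that; the expectation is therefore placed between the two measured azoles rather than at either. For compound 4 the expected step is a 24-fold lower number from compound 1 to compound 4 (1.37 log units; beyond the scatter). Compound 4 is estimated at 30 nM, with a likely range from 8 nM to 120 nM.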

Compound 4, half-maximal inhibitory concentration: 57 nM
The estimate for compound 4 lay 1.9-fold (0.28 log units) below the measured number, within the range that was stated.
By their numbers in this assay, from the lowest: compound 2; then compound 3; then compound 4; then compound 1.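

In this assay, a 12-fold lower number from compound 1 to compound 4 (1.09 log units; beyond the scatter), so the large gain over the 5-methylfuran-2-yl group also holds for a far more heavily substituted azole, and for the much larger (2-ethyl-4-methyl-1-propyl-1H-imidazol-5-yl)methyl group at this position. That gain is only partial when set against the other two azoles: a 7.6-fold higher number from compound 2 to compound 4 (0.88 log units; beyond the scatter), which shows that an imidazole ring alone does not bring compound 4 to the level of compound 2, and a 2.7-fold higher number from compound 3 to compound 4 (0.43 log units; beyond the scatter), which places compound 4 above the 2,5-dimethyl-1,3-thiazol-4-yl compound as well. Nothing available explains why these rings rank as they do.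

As far as these compounds go, the ethyl, methyl and propyl groups all change together from compound 2 to compound 4, so the share of each in the higher number remains open, and a 1-methyl-1H-imidazol-5-yl group would help to separate them. Whether an azole ring is needed at all also remains open, as no six-membered ring such as pyridin-2-yl or a plain phenyl group stands on this saturated chain carbon among the compounds shown.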